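The source may report more compounds than this note shows. Statements on the series, on what has been measured and on what is new or still open speak of the compounds shown alone.

Working notes on the series. In an assay on isolated protein for inhibition of alkaline phosphatase, tissue-nonspecific isozyme (Bos taurus), read by spectrophotometry, with stated times of 7 min and 15 min (on this read-out higher numbers stand for weaker inhibition and lower numbers for stronger inhibition), compound 1 `COc1ccc(Cn2c(-c3ccc(C)cc3)c(-c3ccc(C(F)(F)F)cc3)c(=O)c3cc([N+](=O)[O-])ccc32)cc1` gives 6190 nM, and compound 2 `Cc1ccc(-c2[nH]c3ccc([N+](=O)[O-])cc3c(=O)c2Br)cc1` gives 6470 nM; compound 2 thus holds the higher of the two numbers, but the gap to compound 1 lies within the scatter, so the two are read as equal. Compound 3 `Cc1ccc(-c2[nH]c3ccc([N+](=O)[O-])cc3c(=O)c2-c2ccc(C(F)(F)F)cc2)cc1` differs from compound 2 by 4-(trifluoromethyl)phenyl in place of bromo on an aromatic carbon. Among the compounds with values here, no measured step of this kind exists in the set. Compound 1, which also bears a 4-(trifluoromethyl)phenyl, gives 6190 nM, so no shift beyond the scatter is expected from compound 2 to compound 3: the estimated step is a 1.1-fold lower number from compound 2 to compound 3 (0.03 log units; within the scatter). For compound 3 the expected value in this assay is 6000 nM, within 2500 nM to 15000 nM.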

Compound 3, half-maximal inhibitory concentration: 2690 nM
Beside the measured number, compound 3's estimate is 2.2-fold (0.35 log units) above it, and the stated range covers the measured number.
By their numbers in this assay, from the lowest: compound 3; then compounds 1 and 2 (each within the scatter of the next).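

On the aromatic carbon two atoms from the ring nitrogen, 4-(trifluoromethyl)phenyl in place of bromo gives a 2.4-fold lower number from compound 2 to compound 3 (0.38 log units; beyond the scatter) and so shows that the number responds to the group at this position, which the earlier pair could not show. With 4-(trifluoromethyl)phenyl kept, hydrogen in place of 4-methoxybenzyl on the aromatic nitrogen gives a 2.3-fold lower number from compound 1 to compound 3 (0.36 log units; beyond the scatter) and so ties the lower number to the unsubstituted ring nitrogen in this pair. No evidence bearing on the cause of either step is at hand. Still open, going by these compounds, is how an amine or a carboxylic acid on this aromatic carbon would read, and whether a longer chain on the ring nitrogen would read like 4-methoxybenzyl.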